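The source may report more compounds than this note shows. Statements on the series, on what has been measured and on what is new or still open speak of the compounds shown alone.

Compound 1, `CCCCCCCCCCCCCCCCCCNC(=O)NC(CCC(=O)O)(CCC(=O)O)CCC(=O)O`, in an ADME assay on cells (Epithelial cell, Homo sapiens) for cytotoxicity, read by MTT assay; on this read-out lower numbers stand for an effect already at smaller amounts and higher numbers for an effect only at larger amounts of compound: 280000 nM
Compound 2, `CCCCCCCCCCCCCCNC(=O)NC(CCC(=O)O)(CCC(=O)O)CCC(=O)O`, in this assay: "not determined" (no result reported)

Among the measured compounds shown here, compound 2 stands without a number in this assay, so its result is not known; the only measured anchor is compound 1, which gives 280000 nM in this assay. Compound 3, `CCCCCCCCCCCCCCCCCCCCCCNC(=O)NC(CCC(=O)O)(CCC(=O)O)CCC(=O)O`, differs from compound 2 by octyl in place of hydrogen on a saturated chain carbon, ten or more bonds along the chain from an amide-type nitrogen. For the measured compounds named here, no measured step covers this change, so the direction in this assay is open; with compound 1 as the nearest point, no change beyond the usual scatter is assumed. Compound 3 is therefore expected to give 200000 nM in this assay, estimated within 50000 nM to 600000 nM.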

Compound 3, half-maximal effective concentration: 260000 nM
The estimate for compound 3 lay 1.3-fold (0.11 log units) below the measured number, and the stated range covers the measured number.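

In this assay the butyl difference on a saturated chain carbon reads as a 1.1-fold lower number from compound 1 to compound 3 (0.03 log units; within the scatter) and so stays within the usual scatter. At this position, the longer chain of compound 3 leaves the read-out on the same level as compound 1. Compound 2 has no number, so the octyl difference cannot be read. Nothing offered here bears on the reason for this result. On these data alone, what remains open is how a much shorter chain on the same core would read, and whether an amine in place of a carboxylic acid would leave the read-out unmoved.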